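Dimethoxyphenyl pattern and chloro on the shared core

The compounds below may be only part of what the source reports. "The series", "measured", "known", "first", "only" and "open" are said of these compounds alone.

The shared core carries a (4-methoxyphenyl)(methyl)amino group and a dimethoxyphenyl group on a saturated chain carbon bound to an aromatic nitrogen; the members differ in the methoxy pattern of that group and in one ring substituent. Compound 1 `COc1ccc(N(C)c2ncnc3c2ncn3Cc2ccc(OC)c(OC)c2)cc1` is the parent. In a functional assay on SH-SY5Y cells (Homo sapiens) for antiproliferative activity, read by MTT assay, with a stated time of 48 h (on this read-out lower numbers stand for stronger inhibition of growth and higher numbers for weaker inhibition of growth), compound 1 gives 430 nM. Compound 2 `COc1ccc(N(C)c2ncnc3c2ncn3Cc2cc(OC)cc(OC)c2)cc1` differs from compound 1 by 3,5-dimethoxyphenyl in place of 3,4-dimethoxyphenyl on a saturated chain carbon bound to an aromatic nitrogen. For compound 2 this assay reports only a limit, > 100000 nM. The step of an at least 230-fold higher number from compound 1 to compound 2 (2.36 log units; beyond the scatter) is therefore bounded by the limit of > 100000 nM in this assay, at which 1 of the 3 values shown sits. Compound 3 `COc1ccc(N(C)c2nc(Cl)nc3c2ncn3Cc2ccc(OC)c(OC)c2)cc1` differs from compound 1 in its core by chloro in place of hydrogen on an aromatic carbon. In this assay compound 3 gives 7300 nM, a weakening recorded as a 17-fold higher number from compound 1 to compound 3 (1.23 log units; beyond the scatter).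

Compound 4 `COc1ccc(N(C)c2nc(Cl)nc3c2ncn3Cc2cc(OC)cc(OC)c2)cc1` is not yet measured. It differs from compound 3 by 3,5-dimethoxyphenyl in place of 3,4-dimethoxyphenyl on a saturated chain carbon bound to an aromatic nitrogen, which is the same change as that from compound 1 to compound 2, made here on the chloro-bearing core; the surroundings of the place read the same in both cases. The earlier instance of this change, an at least 230-fold higher number from compound 1 to compound 2 (2.36 log units; beyond the scatter), ran to a limit in this assay. The step from compound 3 to compound 4 is expected to be of comparable size, a 41-fold higher number from compound 3 to compound 4 (1.61 log units; beyond the scatter), because compound 3 starts from 7300 nM and the same change on compound 1 gave an at least 230-fold higher number from compound 1 to compound 2 (2.36 log units; beyond the scatter). Compound 4 is accordingly expected to give 300000 nM in this assay, within 60000 nM to 2000000 nM, most probably returned only as a limit.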

Compound 4, concentration for 50% growth inhibition: > 100000 nM
Compound 4: a limit, no number (the forecaster's own chance of this, stated with the estimate: 85%); the middle value does not contradict the limit.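

In this assay compound 4 is returned only as a limit, > 100000 nM. The change from 3,4-dimethoxyphenyl to 3,5-dimethoxyphenyl therefore weakens growth inhibition on the chloro-bearing core as it does on the core of compound 1, with an at least 13-fold higher number from compound 3 to compound 4 (1.13 log units; beyond the scatter), but agreement in direction is all that can be claimed, and whether the size carries over cannot be settled: the same change on two cores in this assay, an at least 230-fold higher number (2.36 log units; beyond the scatter) from compound 1 to compound 2 and an at least 13-fold higher number (1.13 log units; beyond the scatter) from compound 3 to compound 4; the limit leaves it open whether they differ The step between compound 2 and compound 4 cannot be read, so the effect of chloro in place of hydrogen is seen only with the 3,4-dimethoxyphenyl group, and the full extent of the loss on either core stays hidden: the limit of > 100000 nM in this assay, at which 2 of the 4 values shown sit.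

Still open, going by these compounds, is how the series would respond on the saturated chain carbon to an unsubstituted phenyl, a phenyl carrying a single methoxy, or a phenyl carrying a hydroxy group, any of which could show whether some other group retains growth inhibition. Equally open, on these data alone, is whether an amine or a methyl group on the aromatic carbon that carries chloro would follow compound 3 or compound 1 in this read-out.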